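This account rests on a few compounds, and the source may have more. Where it says the series, first, only, none or still open, it means among the compounds named here.

In a functional assay on Huh-7 cells (Homo sapiens) for inhibition, read by MTT assay, with a stated time of 72 h (on this read-out higher numbers stand for weaker inhibition and lower numbers for stronger inhibition), three compounds have been measured: compound 1 (`CNC(=O)CCCCCCCn1nc(-c2cnc3[nH]ccc3c2)c2c(N)ncnc21`) gives 23500 nM and compound 2 (`Nc1nc2cc(-c3nn(CCCCCCCCCC(=O)NO)c4ncnc(N)c34)ccc2o1`) gives 41200 nM while compound 3 (`Nc1nc2cc(-c3nn(CCCCCCCCC(=O)NO)c4ncnc(N)c34)ccc2o1`) gives 1470 nM as the lowest of the three numbers, beyond the scatter from both others. Compound 4 (`CNC(=O)CCCCCCCn1nc(-c2ccc3oc(N)nc3c2)c2c(N)ncnc21`) alters compound 3 only at the chain end (methylcarbamoyl in place of (hydroxycarbamoyl)methyl on a saturated chain carbon, seven bonds along the chain from an aromatic nitrogen), with methylcarbamoyl in place of (hydroxycarbamoyl)methyl on a saturated chain carbon, seven bonds along the chain from an aromatic nitrogen. Among the measured compounds shown here, the one measured step at this chain end is large (a 28-fold lower number from compound 2 to compound 3 (1.45 log units; beyond the scatter)) and shows how far the number can move there, although both of its compounds keep the hydroxycarbamoyl group. More direct evidence comes from compound 1, which carries the same methylcarbamoyl chain end on a different aromatic group and gives 23500 nM in this assay as its number. A large step towards a higher number is therefore expected (a 12-fold higher number from compound 3 to compound 4 (1.09 log units; beyond the scatter)). Compound 4 is estimated at 18000 nM (expected range 5000 nM to 60000 nM).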

Compound 4, half-maximal inhibitory concentration: 2770 nM
Compound 4: the middle estimate sits 6.5-fold (0.81 log units) above what was measured; the measured number lies below the stated range.
By their numbers in this assay, from the lowest: compounds 3 and 4 (each within the scatter of the next); then compounds 1 and 2 (each within the scatter of the next).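

In this assay, the hydroxycarbamoyl group proves not to be required at this chain end: methylcarbamoyl in place of (hydroxycarbamoyl)methyl gives a 1.9-fold higher number from compound 3 to compound 4 (0.28 log units; within the scatter), so these two chain ends cannot be told apart on this read-out. The outlier is the 2-(hydroxycarbamoyl)ethyl end of compound 2, as shown by a 15-fold lower number from compound 2 to compound 4 (1.17 log units; beyond the scatter). With the methylcarbamoyl chain end held constant, the group on the aromatic carbon also matters, giving an 8.5-fold lower number from compound 1 to compound 4 (0.93 log units; beyond the scatter).

No supporting evidence is available to explain any of these steps. The compounds shown leave open whether a carboxylic acid or an amine at this chain end, or a shorter chain ending in methylcarbamoyl, would stay within the scatter of compound 4.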